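The source may report more compounds than this note shows. Statements on the series, on what has been measured and on what is new or still open speak of the compounds shown alone.

In a functional assay on K562 cells (Homo sapiens) for antiproliferative activity, with a stated time of 72 h (a lower number here means a stronger inhibitor, a higher number a weaker inhibitor), compound 3 (`Cc1cccc(CNc2ncnc3c2ncn3[C@@H]2O[C@H](CO)[C@@H](O)[C@H]2O)c1O`) stands lowest at 18000 nM and compound 1 (`OC[C@H]1O[C@@H](n2cnc3c(NCc4ccc(Br)cc4)ncnc32)[C@H](O)[C@@H]1O`) gives 68200 nM as its reading. Compound 2 (`COc1cccc(CNc2ncnc3c2ncn3[C@@H]2O[C@H](CO)[C@@H](O)[C@H]2O)c1`) reads > 166000 nM and that is a limit of the assay, not a number. Compound 4 (`OC[C@H]1O[C@@H](n2cnc3c(NCc4ccccc4OC(F)F)ncnc32)[C@H](O)[C@@H]1O`) carries 2-(difluoromethoxy)phenyl in place of 2-hydroxy-3-methylphenyl on a saturated chain carbon bound to a nitrogen on an aromatic ring. Two measured steps lead to the group that compound 4 gives up: a 3.8-fold lower number from compound 1 to compound 3 (0.58 log units; beyond the scatter) and an at least 9.2-fold lower number from compound 2 to compound 3 (0.96 log units; beyond the scatter) (both beyond the scatter). The step expected for compound 4 in this assay is therefore modest and toward a higher number, estimated as a 2.8-fold higher number from compound 3 to compound 4 (0.44 log units; beyond the scatter) overall. Compound 4 is expected at 50000 nM within a range from 16000 nM to 160000 nM (estimated).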

Compound 4, half-maximal inhibitory concentration: > 166000 nM
Compound 4 was reported as a limit; the forecaster's own chance of this, stated with the estimate: 20%; at least 3.3-fold (0.52 log units) between middle value and limit.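

In this assay compound 4 gives > 166000 nM, which is a limit of the assay and not a number. This places 2-(difluoromethoxy)phenyl on the weak side at this saturated chain carbon, with an at least 9.2-fold higher number from compound 3 to compound 4 (0.96 log units; beyond the scatter) and an at least 2.4-fold higher number from compound 1 to compound 4 (0.38 log units; beyond the scatter), even though the group leaving and the group entering each count one hydrogen-bond acceptor and only the group leaving counts a donor. The step between compound 2 and compound 4 cannot be read, as both sit at one limit: the limit of > 166000 nM in this assay, at which 2 of the 4 values shown sit.

Still open, going by these compounds, is whether the hydroxyl or the methyl of compound 3 accounts for its lower number, which a plain 2-hydroxyphenyl or 3-methylphenyl group would test. On these data alone, how an amine or a carboxylic acid on the ring would read also remains unknown.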